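Ethyl to Isopropyl Ester: A Step Without a Precedent

A few compounds are considered here, and "the series" means these few. Any claim that something is new, unique, unknown or untested is made for them only; others in the source may bear on it.

Compound 1, `CC1=C(C(=O)OC(C)C)C(c2ccccc2)N/C(=N/C#N)N1`: 6%
Compound 2, `CC1=C(C(=O)OC(C)C)C(C2CCCC2)N/C(=N/C#N)N1`: 3%
Compound 3, `CCOC(=O)C1=C(C)N/C(=N\C#N)NC1c1cccs1`: 3%

All three numbers come from an assay on HeLa cells for displacement of a labelled ligand from adenosine receptor A3 (Homo sapiens), with a stated time of 180 min, tested at 1 uM; a lower number here means less inhibition, a higher number more inhibition at the concentration tested (going by the name of the read-out). Compound 3 stands level with compound 2 at the digits shown, the two together forming the lowest pair of the three, while compound 1 lies a few points higher; every gap among them is within the scatter, so no order among the three can be read. Among the measured compounds shown here, the one step measured between neighbours, a number 3 percentage points lower from compound 1 to compound 2 (within the scatter), swaps the ring on the saturated ring carbon and changes nothing beyond the scatter.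

Compound 4 is `CC1=C(C(=O)OC(C)C)C(c2cccs2)N/C(=N/C#N)N1`. Its difference from compound 3 is methyl in place of hydrogen on a saturated chain carbon bound to an oxygen next to a carbonyl group and a saturated chain carbon. No measured step touches the ester chain, so nothing shown bears directly on this change; what the data do show is that three compounds differing at another position all sit near the same low level. Compound 4 is therefore expected to give about 4%, with a plausible range from -4% to 12%. The estimated step of a number 1 percentage points higher from compound 3 to compound 4 (within the scatter) is expected to stay within the scatter, with no direction favoured.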

Compound 4, a percentage reported as inhibition, at one concentration (the size of the read-out at that concentration, not a potency): 27%
For compound 4 the middle estimate is 23 percentage points below the measured one; measured number outside the range, above it.
By their numbers in this assay, from the lowest: compounds 2, 3 and 1 (each within the scatter of the next); then compound 4.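

In this assay, among the compounds shown here, the ester chain turns out to be a place where a single added methyl can move the number: ethyl to isopropyl with thiophen-2-yl held fixed gives a number 24 percentage points higher from compound 3 to compound 4 (beyond the scatter) and so goes beyond the scatter, which the one earlier step, a number 3 percentage points lower from compound 1 to compound 2 (within the scatter), did not. For the compounds shown here, the ring substituent also proves not to be silent once the isopropyl ester is present, since thiophen-2-yl in place of cyclopentyl gives a number 24 percentage points higher from compound 2 to compound 4 (beyond the scatter) and thiophen-2-yl in place of phenyl gives a number 21 percentage points higher from compound 1 to compound 4 (beyond the scatter), a difference the earlier compounds, which stayed within the scatter of one another, gave no sign of. Among these four compounds the higher number appears only where isopropyl ester and thiophen-2-yl occur together, with compound 3 lacking the first and compounds 1 and 2 lacking the second, and nothing presented here accounts for this.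

The compounds shown leave open whether ethyl to isopropyl would also raise the number with phenyl or cyclopentyl on the saturated ring carbon. They also leave open how the number responds to a tert-butyl ester, a longer chain such as n-butyl, or a carboxylic acid at the ester position.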